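Piperidinyl purines on adenosine A2b: hydroxyphenyl for chlorophenyl

The compounds below may be only part of what the source reports. "The series", "measured", "known", "first", "only" and "open" are said of these compounds alone.

Measured compounds:
- compound 1 `Clc1ccc(-c2nc(N3CCCCC3)c3nc[nH]c3n2)cc1Cl`: 0.7%
- compound 2 `Clc1ccc(-c2nc(N3CCCCC3)c3nc[nH]c3n2)cc1`: 1.4%
- compound 3 `CN1CCN(c2nc(-c3ccc(Cl)c(C(F)(F)F)c3)nc3[nH]cnc23)CC1`: 25.1%

In an assay on cells for displacement of a labelled ligand from adenosine receptor A2b (Homo sapiens), read by scintillation counting and radioligand binding, with a stated time of 30 min, tested at 10 uM (a higher number here means more inhibition at the concentration tested (going by the name of the read-out), a lower number less inhibition), compound 2 gives 1.4%, the second highest of the three numbers. Compound 1 lies nearest, with compound 2 sitting a number 0.7 percentage points higher from compound 1 to compound 2 (within the scatter), a step within the scatter, so the two cannot be ordered. Compound 3 lies furthest: its number in this assay is clearly higher than that of compound 2, and it differs from compound 2 in more than one place, so no single change accounts for the gap.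

Compound 4 `Oc1cccc(-c2nc(N3CCCCC3)c3nc[nH]c3n2)c1` is the next compound in the series. Its change from compound 2 is 3-hydroxyphenyl in place of 4-chlorophenyl on an aromatic carbon. Among the measured compounds shown here, the one measured step that touches the same ring, the loss of chloro from compound 1 to compound 2, was small and within the scatter. For the measured compounds named here, no measured step shows what a hydroxy group on this ring does, and compound 3 carries a different amine and a different aromatic ring and therefore does not bear on the change directly. The expectation is accordingly a step of about a number 3.6 percentage points higher from compound 2 to compound 4 (within the scatter) in this assay, not clearly beyond the scatter, with the number staying low. Compound 4 is estimated at 5%, in a range from -5% to 20%.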

Compound 4, a percentage reported as inhibition, at one concentration (the size of the read-out at that concentration, not a potency): > 80%
Compound 4: only a limit was reported; the forecaster's own chance of this, stated with the estimate: 0%; middle value at least 75 percentage points from the limit.
By their numbers in this assay, from the lowest: compounds 1 and 2 (each within the scatter of the next); then compound 3. At a limit, above all of these: compound 4.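

In this assay, the change on this aromatic carbon, which sits between two ring nitrogen atoms, gives a number at least 78.6 percentage points higher from compound 2 to compound 4 (beyond the scatter). Among the compounds shown here, with the piperidin-1-yl group held constant, the group at this position can therefore move the read-out far beyond the scatter, which the only earlier single-place change, a number 0.7 percentage points higher from compound 1 to compound 2 (within the scatter), gave no sign of. The reading of compound 4 is a limit of the assay and not a number: the limit of > 80% in this assay, at which 1 of the 4 values shown sits.

The step from compound 2 to compound 4 removes the chloro substituent and introduces the hydroxy substituent in one move, so the compounds shown do not separate the contribution of either, and they give no reason for the gap. As far as these compounds go, a methoxy or an amino group in place of the hydroxy in 3-hydroxyphenyl would test how specific the change is, and it remains open whether 3-hydroxyphenyl carries the same gain alongside the amine of compound 3 or another amine, such as morpholine, in place of the piperidin-1-yl group.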